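The compounds below may be only part of what the source reports. "The series", "measured", "known", "first", "only" and "open" are said of these compounds alone.

Measured compounds:
- compound 2, `O=C(Nc1cccc(-c2oc3cc(-c4ccc(F)cc4)ccc3c(=O)c2O)c1)c1cc(F)cc(F)c1`: 7410 nM
- compound 1, `O=C(Nc1cccc(-c2oc3cc(-c4ccc(F)cc4)ccc3c(=O)c2O)c1)c1ccccc1F`: 17400 nM

Compound 2 holds the lower of the two numbers in a functional assay on GTL 16 cells for antiproliferative activity against GTL 16 cell line (Homo sapiens), read by CCK-8 assay, with a stated time of 72 h; a higher number here means a weaker inhibitor, a lower number a stronger inhibitor; compound 1 sits at the higher one, the step of a 2.3-fold lower number from compound 1 to compound 2 (0.37 log units; beyond the scatter).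

Compound 3, `CCCc1ccc(C(=O)Nc2cccc(-c3oc4cc(-c5ccc(F)cc5)ccc4c(=O)c3O)c2)cc1`, is not yet measured. Its change from compound 2: 4-propylphenyl in place of 3,5-difluorophenyl on a carbonyl carbon. For the measured compounds named here, the one known step touches the same aryl on the carbonyl carbon, but from 2-fluorophenyl to 3,5-difluorophenyl; no step exchanges a fluorinated aryl for a propyl-bearing one, so it is not directly comparable. Only a modest shift in either direction is expected. Compound 3 is estimated at 8000 nM (range 2500 nM to 25000 nM), the expected step being a 1.1-fold higher number from compound 2 to compound 3 (0.03 log units; within the scatter).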

Compound 3, half-maximal inhibitory concentration: 20400 nM
Compound 3: the middle estimate sits 2.6-fold (0.41 log units) below what was measured; the range from low to high includes it.
By their numbers in this assay, from the lowest: compound 2; then compounds 1 and 3 (each within the scatter of the next).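

In this assay, 4-propylphenyl on the carbonyl carbon gives a 2.8-fold higher number from compound 2 to compound 3 (0.44 log units; beyond the scatter), so this fluorine-free aryl does not keep the level of 3,5-difluorophenyl. Against 2-fluorophenyl, the same group gives a 1.2-fold higher number from compound 1 to compound 3 (0.07 log units; within the scatter), which leaves 3,5-difluorophenyl as the only one of the three aryls standing apart, with its steps to both others beyond the scatter. Nothing available bears on the cause of these steps.

Open, from the compounds shown here alone, is whether a shorter chain such as methyl, a longer chain such as pentyl, or an amine on this aryl would match compound 2 or fall with compound 3.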